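Swapping the Amine Chain for Chloro in Compound 4

The source may report more compounds than this note shows. Statements on the series, on what has been measured and on what is new or still open speak of the compounds shown alone.

Of the compounds shown here, three have been tested in a functional assay on SK-OV-3 cells (Homo sapiens) for cytotoxicity, read by MTT assay, with a stated time of 48 h; on this read-out lower numbers stand for stronger inhibition and higher numbers for weaker inhibition. Among the measured compounds shown here, compound 1 `CC(C)COc1ccc2c(Cl)ccnc2c1` gives 3190 nM, and compound 2 `CCCCOc1ccc2c(Cl)ccnc2c1` gives 4130 nM; the only single-point comparison among them is a 1.3-fold higher number from compound 1 to compound 2 (0.11 log units; within the scatter). Compound 3 `CN(C)CCNc1ccnc2cc(OCc3ccccc3)ccc12` gives 2350 nM, a number that lies within the usual scatter of both compound 1 and compound 2, so no order can be read among the three.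

Compound 4 `Clc1ccnc2cc(OCc3ccccc3)ccc12` differs from compound 3 by chloro in place of (2-(dimethylamino)ethyl)amino on an aromatic carbon. For the measured compounds named here, none of the measured steps concerns this exchange: the step from compound 1 to compound 2 alters only the alkoxy chain. What can be said is that compound 1 and compound 2 already carry the chloro group that enters here, and their numbers sit close to that of compound 3. Compound 4 is therefore expected to give a number near the present cluster, with a 1.5-fold higher number from compound 3 to compound 4 (0.17 log units; within the scatter) no larger than the scatter. The estimate for compound 4 in this assay is 3500 nM, between 1500 nM and 8000 nM.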

Compound 4, half-maximal inhibitory concentration: 5170 nM
The estimate for compound 4 lay 1.5-fold (0.17 log units) below the measured number; the measured number falls inside the stated range.
By their numbers in this assay, from the lowest: compounds 3, 1, 2 and 4 (each within the scatter of the next, the first and the last beyond it).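

In this assay, among the compounds shown here, putting chloro in place of (2-(dimethylamino)ethyl)amino on this aromatic carbon opposite the ring nitrogen gives a 2.2-fold higher number from compound 3 to compound 4 (0.34 log units; beyond the scatter) and is the first step to pass the scatter. For the compounds shown here, with chloro in place, the group on the oxygen gives no such step: phenyl in place of propyl gives a 1.3-fold higher number from compound 2 to compound 4 (0.10 log units; within the scatter) and phenyl in place of isopropyl gives a 1.6-fold higher number from compound 1 to compound 4 (0.21 log units; within the scatter) and neither can be read as a change. No measurement here bears on what lies behind the step at the aromatic carbon.

Going by these compounds, it remains open whether a plain amino group or a longer chain ending in a diethylamine would keep the number of compound 3 at this position. Also open, on these data alone, is whether (2-(dimethylamino)ethyl)amino would give a similar step alongside the propyl or isopropyl ethers.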